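A Hydroxy Group in Place of an Ethyl Arm

The compounds below may be only part of what the source reports. "The series", "measured", "known", "first", "only" and "open" are said of these compounds alone.

Three compounds have been tested in a functional assay on the whole organism (Tail, strain ICR) with Mus musculus as the target, in the tail flick test, with a stated time of 150 min, at a dose of 25 umol/kg by the oral route; on this read-out lower numbers stand for a weaker effect and higher numbers for a stronger effect at the one dose given:

compound 1 `O=C(O)[C@@H]1CCCN1C(=O)CN(c1nc(Cl)nc2[nH]cnc12)C1CC1` gives 7.29%
compound 2 `CC[C@H](C)[C@H](NC(=O)CN(c1ncnc2c1ncn2C1CCCCO1)C1CC1)C(=O)OCc1ccccc1` gives 16.4%
compound 3 `O=C(CN(c1nc(Cl)nc2[nH]cnc12)C1CC1)N[C@@H](CO)C(=O)O` gives 18.8%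

On these numbers compound 2 sits between the other two, yet its gaps to compound 3 and to compound 1 both lie within the scatter, so no order among the three can be read from them. Compound 4 `C[C@@H](O)[C@H](NC(=O)CN(c1ncnc2c1ncn2C1CCCCO1)C1CC1)C(=O)OCc1ccccc1` differs from compound 2 by hydroxy in place of ethyl on a saturated chain carbon bound to two saturated chain carbons. Going by the values given here, the one measured step, a number 11.5 percentage points higher from compound 1 to compound 3 (beyond the scatter), changes a different part of the molecule and does not test ethyl against hydroxy, so no measured step bears directly on this change. Compound 4 is therefore expected to give about 16%, between 5% and 30%. The estimated step of a number 0.4 percentage points lower from compound 2 to compound 4 (within the scatter) is expected to stay within the scatter.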

Compound 4, a percentage reported as activity, at one dose (the size of the read-out at that dose, not a potency): 6.53%
Estimate against measurement, compound 4: 9.5 percentage points above; measured number inside the range.
By their numbers in this assay, from the lowest: compounds 4, 1, 2 and 3 (each within the scatter of the next, the first and the last beyond it).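

In this assay, putting hydroxy in place of ethyl on a saturated chain carbon bound to two saturated chain carbons gives a number 9.9 percentage points lower from compound 2 to compound 4 (within the scatter). Going by these compounds alone, this is the first direct reading of this change at this position, and it cannot be told apart from repeat-to-repeat variation, so ethyl and hydroxy cannot be ranked here. No separate measurement is available to help interpret this result.

Going by these compounds, whether an amine, a carboxylic acid or a longer chain at this position would give a clearer step stays open.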